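The source may report more compounds than this note shows. Statements on the series, on what has been measured and on what is new or still open speak of the compounds shown alone.

Compound 1 `N#Cc1cnc(NCc2cnccc2C(F)(F)F)cc1NC1CCOCC1` is the weakest of the three measured compounds on the numbers shown. In an assay on isolated protein for inhibition of protein kinase C theta type (Homo sapiens), read by TR-FRET, with a stated time of 2 h (on this read-out higher numbers stand for weaker inhibition and lower numbers for stronger inhibition), compound 1 gives 900 nM, a number that stands beyond the scatter above both of the others. The closest of them is compound 3 `CC(C)(C)Oc1ncncc1CNc1cc(N[C@H]2CC[C@@H](O)CC2)c(C#N)cn1`, which in this assay gives 200 nM. Going by the values given here, the furthest is compound 2 `N#Cc1cnc(NCc2ccccc2C(F)(F)F)cc1N[C@H]1CC[C@@H](C(N)=O)CC1`, which in this assay gives 20 nM; no single-change step links compound 2 to compound 1, so only their two values can be compared.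

Compound 4 `CC1(C)[C@@H](Nc2cc(NCc3cnccc3C(F)(F)F)ncc2C#N)C[C@H]1C(N)=O` has not yet been measured. It keeps the core of compound 1 and differs from it in one place: 3-carbamoyl-2,2-dimethylcyclobutyl in place of oxan-4-yl on a nitrogen on an aromatic ring. Among the compounds with values here, the group that enters carries a carbamoyl, and the one measured compound that also carries a carbamoyl on its saturated ring, compound 2, gives the lowest number of the set.

On that basis a step from compound 1 to compound 4 toward a lower number, beyond the scatter, is expected, though smaller than the gap between compound 1 and compound 2, since compound 2 differs in more than one place. Compound 4 is expected to give 120 nM, with a range from 30 nM to 450 nM, which would mean a step of a 7.5-fold lower number from compound 1 to compound 4 (0.88 log units; beyond the scatter).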

Compound 4, half-maximal inhibitory concentration: 140 nM
Estimate against measurement, compound 4: 1.2-fold (0.07 log units) below; low and high end bracket the measured number.
By their numbers in this assay, from the lowest: compound 2; then compounds 4 and 3 (each within the scatter of the next); then compound 1.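

On the core of compound 1, the group on a nitrogen on an aromatic ring proves able to move the number in this assay: 3-carbamoyl-2,2-dimethylcyclobutyl in place of oxan-4-yl gives a 6.4-fold lower number from compound 1 to compound 4 (0.81 log units; beyond the scatter), a step beyond the scatter. Going by these compounds alone, the earlier compounds differed from one another in more than one place, so their gaps could not be assigned to this position alone; this is the first comparison in which the rest of the molecule stays fixed. Nothing shown gives a measured account of why the number moves.

The step removes one ring and brings in a carbamoyl, two methyl groups, a four-membered ring and two defined stereocentres all at once, so the share of each remains unresolved. A 3-carbamoylcyclobutyl group without the two methyl groups, or a carboxylic acid or an amine in place of the carbamoyl on the same ring, would begin to separate these contributions at this position.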